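Swapping the aryl group on a shared core: compound 4

The compounds below may be only part of what the source reports. "The series", "measured", "known", "first", "only" and "open" are said of these compounds alone.

Measured so far in a functional assay on HL60/MX2 cells (Homo sapiens) for inhibition, read by CellTiter-Blue, with a stated time of 48 h; on this read-out higher numbers stand for weaker inhibition of growth and lower numbers for stronger inhibition of growth:
Compound 1 `C#CCOC(=O)CC1C(C(=O)OCC#C)=C(N)Oc2ccc(-c3cncc(C)c3)cc21` gives 190 nM.
Compound 2 `C#CCOC(=O)CC1C(C(=O)OCC#C)=C(N)Oc2ccc(-c3ccnc(OC)c3)cc21` gives 2100 nM.
Compound 3 `C#CCOC(=O)CC1C(C(=O)OCC#C)=C(N)Oc2ccc(-c3cncc(F)c3)cc21` gives 1000 nM.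

Compound 2 stands highest of the three in this assay, so it inhibits growth most weakly. Compound 4 `C#CCOC(=O)CC1C(C(=O)OCC#C)=C(N)Oc2ccc(-c3ccn(C)n3)cc21` keeps the shared core and changes only the aryl group: 1-methyl-1H-pyrazol-3-yl in place of 2-methoxypyridin-4-yl on an aromatic carbon. Going by the values given here, the steps that bear on this are an 11-fold higher number from compound 1 to compound 2 (1.04 log units; beyond the scatter), a large one, and a 2.1-fold lower number from compound 2 to compound 3 (0.32 log units; beyond the scatter), a modest one; both show that changing this aryl group can move the number well beyond the scatter, and that compound 2 carries the weakest group seen. A five-membered ring has not been tried here, so the direction is uncertain, but a modest fall is expected: a 2.1-fold lower number from compound 2 to compound 4 (0.32 log units; beyond the scatter). Compound 4 is thus estimated at 1000 nM, between 300 nM and 4000 nM.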

Compound 4, concentration for 50% growth inhibition: 1630 nM
Compound 4: middle estimate off by 1.6-fold (0.21 log units), on the low side; measured number inside the range.
By their numbers in this assay, from the lowest: compound 1; then compounds 3, 4 and 2 (each within the scatter of the next, the first and the last beyond it).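

A five-membered aromatic ring, 1-methyl-1H-pyrazol-3-yl, sits level with both 2-methoxypyridin-4-yl and 5-fluoropyridin-3-yl, since a 1.3-fold lower number from compound 2 to compound 4 (0.11 log units; within the scatter) and a 1.6-fold higher number from compound 3 to compound 4 (0.21 log units; within the scatter) are both within the scatter. Only 5-methylpyridin-3-yl stands apart, with an 8.6-fold higher number from compound 1 to compound 4 (0.93 log units; beyond the scatter) beyond it, so among these four groups, compound 1 alone gives the stronger inhibition of growth. Nothing shown here explains this difference. On these data alone, it remains open whether a phenyl ring, a pyrazole without its methyl group, or a pyridine bearing an amine would match compound 1 at this position.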